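Cytotoxicity notes on the triazolylpyridine semicarbazone series

The compounds below may be only part of what the source reports. "The series", "measured", "known", "first", "only" and "open" are said of these compounds alone.

Measured compounds:
- compound 1, `COc1ccc(OC)c(/C=N/NC(=O)Nc2ccc(Oc3ccnc(-c4nncn4CCN(C)C)c3)c(F)c2)c1`: in an ADME assay on WI-38 cells (Homo sapiens) for cytotoxicity, read by MTT assay, with a stated time of 72 h (a lower number here means a stronger inhibitor, a higher number a weaker inhibitor), compound 1 gives "not determined" (no result reported)
- compound 2, `CN(C)CCn1cnnc1-c1cc(Oc2ccc(NC(=O)N/N=C/c3ccc(F)cc3F)cc2F)ccn1`: in this assay compound 2 gives 5030 nM
- compound 3, `CN(C)CCn1cnnc1-c1cc(Oc2ccc(NC(=O)N/N=C/c3ccc(O)c(O)c3)cc2F)ccn1`: in this assay compound 3 gives "not determined" (no result reported)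

Only compound 2 carries a number in this assay. Compound 1 and compound 3 have no result, so compound 3 stands without a value of its own, and one further entry in the set is equally blank. Nothing can be said about an order among compound 1, compound 2 and compound 3.

Compound 4, `CN(C)CCn1cnnc1-c1cc(Oc2ccc(NC(=O)N/N=C/c3c(O)ccc4ccccc34)cc2F)ccn1`, is the next entry to be tested in this assay. It differs from compound 3 in one place: 2-hydroxynaphthalen-1-yl in place of 3,4-dihydroxyphenyl on a carbon with a double bond to nitrogen. Among the compounds with values here, no step between two measured compounds is known, so there is no basis for a direction; the working expectation is a step no larger than the usual scatter, in either direction.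

With compound 2 as the only anchor, giving 5030 nM in this assay, compound 4 is expected to land near 6000 nM, estimated between 1500 nM and 25000 nM.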

Compound 4, half-maximal inhibitory concentration: 3250 nM
For compound 4 the middle estimate is 1.8-fold (0.27 log units) above the measured one; low and high end bracket the measured number.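

In this assay, within the data shown here, there is a 1.5-fold lower number from compound 2 to compound 4 (0.19 log units; within the scatter) and this is the first readable step. On a carbon with a double bond to nitrogen, 2,4-difluorophenyl and the two-ring 2-hydroxynaphthalen-1-yl can therefore be exchanged without a difference beyond the usual scatter, so a second aromatic ring and a hydroxyl group on this carbon are compatible with a value in the same range as compound 2 gives. No supporting measurement bears on this result.

Steps involving compound 1 or compound 3 cannot be read, so the effect of 3,4-dihydroxyphenyl at this position remains unknown. On these data alone, whether a carboxylic acid or an amine on this carbon would also stay within the scatter of compound 2 remains open.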